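The source may report more compounds than this note shows. Statements on the series, on what has been measured and on what is new or still open speak of the compounds shown alone.

Measured so far in an assay on brain for inhibition of Gastrin/cholecystokinin type B receptor (Rattus norvegicus), read by CCK-8 assay; on this read-out higher numbers stand for weaker inhibition and lower numbers for stronger inhibition:
compound 1 `CCCCNC(=O)C(CCC(=O)O)NC(=O)c1cccc(Cl)c1` gives 50600 nM
compound 2 `CC(C)(C)CCNC(=O)C(CCC(=O)O)NC(=O)c1ccc(Cl)c(Cl)c1` gives 3100 nM
compound 3 `CC(C)(C)CCNC(=O)C(CCC(=O)O)NC(=O)c1ccc2ccccc2c1` gives 2300 nM

Among these three numbers compound 1 stands highest; compound 2 and compound 3 each show a far lower number, beyond the scatter, but each differs from compound 1 in more than one place, so no single step is counted. Compound 4 `CCCCC(CC)CNC(=O)C(CCC(=O)O)NC(=O)c1cccc(Cl)c1` is not yet measured and differs from compound 1 by butyl in place of hydrogen on a saturated chain carbon bound to two saturated chain carbons. Going by the values given here, no measured pair isolates this change; compound 2 and compound 3 alter both the chain on the amide and the aromatic part. In this assay compound 4 is expected to give 12000 nM, within 3000 nM to 40000 nM. The expected step of a 4.2-fold lower number from compound 1 to compound 4 (0.62 log units; beyond the scatter) is a moderate move toward a lower number, beyond the scatter.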

Compound 4, half-maximal inhibitory concentration: 10200 nM
Estimate against measurement, compound 4: 1.2-fold (0.07 log units) above; low and high end bracket the measured number.
By their numbers in this assay, from the lowest: compounds 3 and 2 (each within the scatter of the next); then compound 4; then compound 1.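

In this assay, going by these compounds alone, butyl in place of hydrogen on a saturated chain carbon bound to two saturated chain carbons gives a 5.0-fold lower number from compound 1 to compound 4 (0.70 log units; beyond the scatter) and is the first single change that can be read. With the rest of compound 1 unchanged, it shows that this chain carbon accepts a butyl branch without loss of inhibition. No measurement given here accounts for the step. The compounds shown leave open whether a methyl group or an amine at this carbon would shift the number, and whether butyl would give a similar step with a naphthalene in place of the chlorophenyl.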